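The source may hold more compounds than are shown below. What is called first, only, known or untested is meant among the compounds shown, and "the series" means these compounds.

Compound 2, `CCn1ncc2c(Nc3ccc(OC(F)(F)F)cc3)ncnc21`, is the starting point. In an ADME assay on BaF3 cells (Mus musculus) for cytotoxicity (on this read-out lower numbers stand for an effect already at smaller amounts and higher numbers for an effect only at larger amounts of compound), compound 2 reaches only a limit of the assay, > 10000 nM. Compound 3, `FC(F)(F)Oc1ccc(Nc2cc(-c3ccncc3)ncn2)cc1`, also sits at a limit in this assay, > 10000 nM. Compound 1, `Cc1ccc(NC(=O)c2cccc(C(F)(F)F)c2)cc1C(=O)c1cc2c(Nc3ccc(OC(F)(F)F)cc3)ncnc2s1`, is the only one of the three with a number: in this assay compound 1 gives 8900 nM. Compound 2 therefore stands where two of the three measured compounds sit, at the limit of > 10000 nM in this assay, at which 2 of the 3 values shown sit, and how far beyond that point compound 2 lies cannot be read from these numbers. For the measured compounds named here, no pair of measured compounds differs in one place, so no measured step is known.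

Compound 4, `CCCn1ncc2c(Nc3ccc(OC(F)(F)F)cc3)ncnc21`, is not yet measured. Its difference from compound 2 is methyl in place of hydrogen on a saturated chain carbon, two bonds along the chain from an aromatic nitrogen: a hydrogen leaves and a methyl enters, on a saturated chain carbon, two bonds along the chain from an aromatic nitrogen; cut one bond further out, ethyl becomes propyl. For such a change the expected step is a step that the limit leaves unreadable from compound 2 to compound 4, within the usual scatter, because the limit of > 10000 nM in this assay, at which 2 of the 3 values shown sit, already holds compound 2 and a change of one carbon gives no ground for a larger move. The estimate for compound 4 in this assay is 15000 nM, between 5000 nM and 40000 nM, most likely again reported only as a limit.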

Compound 4, half-maximal effective concentration: 6600 nM
Beside the measured number, compound 4's estimate is 2.3-fold (0.36 log units) above it; low and high end bracket the measured number.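

Lengthening the chain by one carbon, from ethyl to propyl, gives the first readable number for a compound with a chain at this position: in this assay the change gives an at least 1.5-fold lower number from compound 2 to compound 4 (0.18 log units; that floor lies within the scatter). For the compounds shown here, that figure is only a floor, and the true size of the step stays hidden, because one end of it rests on a limit: the limit of > 10000 nM in this assay, at which 2 of the 4 values shown sit. Even so, this is the first measured pair that differs in one place, which makes the chain on the aromatic nitrogen the first site where a single change can be followed, although the floor alone does not settle whether the added methyl moves the read-out beyond ordinary scatter.

The compounds shown leave open what a longer chain such as butyl, a branched chain such as isopropyl, or a chain ending in an amine or a hydroxyl group would do at this place. They also leave open whether the same change from ethyl to propyl would give a similar step on a different core, such as the core of compound 1.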